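This account rests on a few compounds, and the source may have more. Where it says the series, first, only, none or still open, it means among the compounds named here.

Measured in a functional assay with Mus musculus as the target; on this read-out lower numbers stand for an effect already at smaller amounts and higher numbers for an effect only at larger amounts of compound:
- compound 1 `Nc1nc(O)c2c(n1)n(C1OC(CO)[C@@H](O)[C@H]1O)c(=O)n2C/C=C/c1ccccc1`: 4 uM
- compound 2 `COc1ccc(Cn2c(=O)n(C3OC(CO)[C@@H](O)[C@H]3O)c3nc(N)nc(O)c32)cc1`: 2 uM
- compound 3 `CCCCCCn1c(=O)n(C2OC(CO)[C@@H](O)[C@H]2O)c2nc(N)nc(O)c21`: 600 uM

Compound 3 has the highest number of the three in this assay, and its gaps to the other two lie beyond the scatter. Compound 4 `CCCCn1c(=O)n(C2OC(CO)[C@@H](O)[C@H]2O)c2nc(N)nc(O)c21` differs from it at the end of the chain: hydrogen in place of ethyl on a saturated chain carbon, four bonds along the chain from an aromatic nitrogen. In other words, hydrogen stands in place of ethyl on a saturated chain carbon, four bonds along the chain from an aromatic nitrogen.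

Among the measured compounds shown here, no measured step shortens a chain, so the evidence is indirect. The closest steps are a 150-fold higher number from compound 1 to compound 3 (2.18 log units; beyond the scatter) and a 300-fold higher number from compound 2 to compound 3 (2.48 log units; beyond the scatter), both large and both with pentyl entering. By contrast, the step between the two other groups is a 2.0-fold lower number from compound 1 to compound 2 (0.30 log units; within the scatter). These steps show how far the number can move at this site, not what shortening does. A partial move toward a lower number is therefore expected, stopping short of the values of compound 1 and compound 2.

The expected step, with wide uncertainty, is a 7.5-fold lower number from compound 3 to compound 4 (0.88 log units; beyond the scatter). Compound 4 is estimated at 80 uM, within an expected range of 10 uM to 600 uM.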

Compound 4, concentration for half-maximal effect: 100 uM
The estimate for compound 4 lay 1.3-fold (0.10 log units) below the measured number; measured number inside the range.
By their numbers in this assay, from the lowest: compounds 2 and 1 (each within the scatter of the next); then compound 4; then compound 3.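

In this assay, the change of pentyl to propyl on a saturated chain carbon bound to an aromatic nitrogen gives a 6.0-fold lower number from compound 3 to compound 4 (0.78 log units; beyond the scatter), the first sign that chain length alone moves the number at this position. The gaps to the 4-methoxyphenyl and 2-phenylethenyl groups remain large, at a 50-fold higher number from compound 2 to compound 4 (1.70 log units; beyond the scatter) and a 25-fold higher number from compound 1 to compound 4 (1.40 log units; beyond the scatter), so this shortening closes only part of the distance to either group. The data shown offer no explanation for these shifts.

With only two simple alkyl chains, a single step cannot show whether a still shorter chain such as ethyl or methyl would lower the number further. On these data alone, it also remains open how an amine or a carboxylic acid in place of the ethyl would compare.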